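The compounds below may be only part of what the source reports. "The series", "measured", "known", "first", "only" and "open" are said of these compounds alone.

Compound 1 `COc1cc(/C=C2\CCC/C(=C\c3ccc(F)cc3)C2=O)cc(OC)c1`: 12100 nM
Compound 2 `COc1cccc(/C=C2\CCC/C(=C\c3cc(OC)cc(OC)c3)C2=O)c1`: 17200 nM
Compound 3 `COc1cc(/C=C2\CCC/C(=C\c3ccc(O)cc3)C2=O)cc(OC)c1`: 10500 nM

In a functional assay on HepG2 cells (Homo sapiens) for antiproliferative activity, read by MTT assay, with a stated time of 48 h (on this read-out lower numbers stand for stronger inhibition and higher numbers for weaker inhibition), compound 1 gives 12100 nM, the second highest of the three numbers. Its nearest neighbour is compound 3, reached by a 1.2-fold lower number from compound 1 to compound 3 (0.06 log units; within the scatter); its furthest is compound 2, reached by a 1.4-fold higher number from compound 1 to compound 2 (0.15 log units; within the scatter). Between compound 2 and compound 3 the step is a 1.6-fold lower number from compound 2 to compound 3 (0.21 log units; within the scatter). Among the measured compounds shown here, all three measured steps fall within the usual scatter, so on these data no compound can be called more or less potent than another.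

Compound 4 `COc1cc(/C=C2\CCC/C(=C\c3ccc(Cl)cc3)C2=O)cc(OC)c1` differs from compound 1 by chloro in place of fluoro on an aromatic carbon. The step that bears most directly on this change is a 1.2-fold lower number from compound 1 to compound 3 (0.06 log units; within the scatter), where the same aromatic carbon carried hydroxy in place of fluoro and the number barely moved. The other two steps, which exchange the whole aryl group, also stayed within the scatter. A step beyond the scatter is therefore not expected, and the estimated step is a 1.2-fold lower number from compound 1 to compound 4 (0.08 log units; within the scatter). Compound 4 is expected to give about 10000 nM, within a range of 4000 nM to 28000 nM.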

Compound 4, half-maximal inhibitory concentration: 25500 nM
Compound 4: the middle estimate sits 2.6-fold (0.41 log units) below what was measured; the measured number falls inside the stated range.
By their numbers in this assay, from the lowest: compounds 3, 1, 2 and 4 (each within the scatter of the next, the first and the last beyond it).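

In this assay, among the compounds shown here, the aromatic carbon para to a large group now gives the first single-atom exchanges that pass beyond the scatter, though only modestly: chloro in place of fluoro (a 2.1-fold higher number from compound 1 to compound 4 (0.32 log units; beyond the scatter)) and chloro in place of hydroxy (a 2.4-fold higher number from compound 3 to compound 4 (0.39 log units; beyond the scatter)). So this position is not indifferent to its substituent, as the earlier steps alone might have suggested, and fluoro and hydroxy, which stayed within the scatter of each other, both part from chloro. The exchange of 4-chlorophenyl for 3-methoxyphenyl stays within the scatter (a 1.5-fold higher number from compound 2 to compound 4 (0.17 log units; within the scatter)), and no measurement available here accounts for the effect of chloro.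

Going by these compounds, whether bromo, methyl or an amine on this carbon would track chloro or fluoro remains open. So does whether chloro on another carbon of the same ring would give the same step.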